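A Shorter Amine Tail on a Compound with a Low Inhibition Reading

The compounds below may be only part of what the source reports. "The series", "measured", "known", "first", "only" and "open" are said of these compounds alone.

Three ureas share one core and differ only in the substitution of the outer phenyl urea. In an assay on isolated protein for inhibition of proto-oncogene tyrosine-protein kinase receptor Ret (Homo sapiens), read by mobility shift assay, with a stated time of 1 h, tested at 10 uM (a higher number here means more inhibition at the concentration tested (going by the name of the read-out), a lower number less inhibition), compound 1 `CCN(CC)CCn1cnnc1-c1cc(Oc2ccc(NC(=O)Nc3ccccc3C(F)(F)F)cc2F)ccn1` gives "not determined" (no result reported). In this assay compound 3 `CCN(CC)CCn1cnnc1-c1cc(Oc2ccc(NC(=O)Nc3ccc(Cl)cc3Cl)cc2F)ccn1` gives "not determined" (no result reported). Going by the values given here, compound 2 `CCN(CC)CCn1cnnc1-c1cc(Oc2ccc(NC(=O)Nc3ccc(F)c(Cl)c3)cc2F)ccn1` is the only member with a number: in this assay compound 2 gives 1.9%, a reading that lies within the usual scatter of no inhibition at all. Since nothing else was measured, compound 2 stands alone among the numbers shown, and no comparison between measured compounds can be made.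

Compound 4 `CN(C)CCCn1cnnc1-c1cc(Oc2ccc(NC(=O)Nc3ccc(F)c(Cl)c3)cc2F)ccn1` differs from compound 2 only in the chain attached to the core: (dimethylamino)methyl in place of diethylamino on a saturated chain carbon, two bonds along the chain from an aromatic nitrogen. Among the compounds with values here, the data hold no step that would show what such a change does here. Because compound 2 gives 1.9%, there is little room for a further drop, and no ground to expect a rise. The step that this estimate means is expected to be none beyond the scatter: a number 1.1 percentage points higher from compound 2 to compound 4 (within the scatter). Compound 4 is therefore expected to give 3%, with a likely range from -8% to 15%.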

Compound 4, a percentage reported as inhibition, at one concentration (the size of the read-out at that concentration, not a potency): 45.5%
For compound 4 the middle estimate is 42.5 percentage points below the measured one, and the stated range ends below it.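

In this assay the change from 2-(diethylamino)ethyl to 3-(dimethylamino)propyl gives a number 43.6 percentage points higher from compound 2 to compound 4 (beyond the scatter) and shows that the reading responds strongly to this chain, even with the outer phenyl urea unchanged. The change alters both the groups on the amine and the length of the chain in a single step, and this one pair cannot tell which of the two carries the gain. Nothing measured here accounts for the rise.

A 3-(diethylamino)propyl or a 2-(dimethylamino)ethyl chain would separate those two parts, and a morpholine on the same chain would test whether an open-chain amine is needed at all. On these data alone, it also remains open whether 3-(dimethylamino)propyl gives a similar step with the outer phenyl ureas of compound 1 and compound 3.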